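The source may report more compounds than this note shows. Statements on the series, on what has been measured and on what is new or still open speak of the compounds shown alone.

- compound 1 `COc1ccc2nc(NC(=O)CCCCC(=O)NO)sc2c1`: 21.4 ug/mL
- compound 2 `O=C(CCCCCCC(=O)Nc1nc2ccccc2s1)NO`: 5.71 ug/mL
- compound 3 `Cc1ccc2nc(NC(=O)CCCCC(=O)NO)sc2c1`: 11 ug/mL

In a functional assay on NCI-H460 cells (Homo sapiens) for cytotoxicity (on this read-out higher numbers stand for weaker inhibition and lower numbers for stronger inhibition), compound 3 stands in the middle of the three numbers, although its gaps to compound 1 and compound 2 both lie within the scatter. Moving to compound 4 `O=C(CCCCC(=O)Nc1nc2ccccc2s1)NO` is a small edit: hydrogen in place of methyl on an aromatic carbon. In words, this is hydrogen in place of methyl on an aromatic carbon, with the chain left as it is.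

Among the compounds with values here, one measured step bears directly on this, because it changes the same aromatic carbon: a 1.9-fold lower number from compound 1 to compound 3 (0.29 log units; within the scatter). Compound 2 also carries hydrogen at that carbon, but its chain is longer, so it offers no clean comparison. Given a 1.9-fold lower number from compound 1 to compound 3 (0.29 log units; within the scatter), no step beyond the scatter is expected in this assay. The expected change is small: a 1.1-fold higher number from compound 3 to compound 4 (0.04 log units; within the scatter).

For compound 4 the estimated value is 12 ug/mL, with an expected range from 6 ug/mL to 24 ug/mL.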

Compound 4, half-maximal inhibitory concentration: 14.4 ug/mL
Compound 4: the middle estimate sits 1.2-fold (0.08 log units) below what was measured, within the range that was stated.
By their numbers in this assay, from the lowest: compounds 2, 3, 4 and 1 (each within the scatter of the next, the first and the last beyond it).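

In this assay, swapping the methyl on the aromatic carbon for hydrogen leaves the number within the scatter (a 1.3-fold higher number from compound 3 to compound 4 (0.12 log units; within the scatter)), and so does swapping methoxy for hydrogen at that same carbon (a 1.5-fold lower number from compound 1 to compound 4 (0.17 log units; within the scatter)), so these three groups cannot be told apart here. The step that does pass the scatter lies in the chain, with hydroxycarbamoyl in place of 2-(hydroxycarbamoyl)ethyl giving a modest shortening effect on the read-out (a 2.5-fold higher number from compound 2 to compound 4 (0.40 log units; beyond the scatter)). No supporting measurement is available to explain either result.

From the compounds shown here alone, what an amine or a carboxylic acid on that aromatic carbon would do remains open. Going by these compounds, it is also open whether a chain longer than that of compound 2 would move the number further.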